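This account rests on a few compounds, and the source may have more. Where it says the series, first, only, none or still open, it means among the compounds named here.

Measured so far in an ADME assay on THP-1 cells (Homo sapiens) for cytotoxicity, read by MTT assay, tested at 50 ug/mL; a higher number here means more inhibition at the concentration tested (going by the name of the read-out), a lower number less inhibition:
Compound 1, `Brc1ccc(-c2csc(N/N=C/c3ccc(-n4ccnc4)cc3)n2)cc1`: in this assay compound 1 gives 36.8%.
Compound 2, `Clc1ccc(-c2csc(N/N=C/c3ccc(-n4ccnc4)cc3)n2)c(Cl)c1`: in this assay compound 2 gives 28.8%.
Compound 3, `Brc1ccc(-c2csc(N/N=C/c3ccc(-n4cncn4)cc3)n2)cc1`: in this assay compound 3 gives 32.6%.

Compound 2 is obtained from compound 1 by one change, (2,4-dichlorophenyl in place of 4-bromophenyl on an aromatic carbon), and the measured step that went with it is a number 8 percentage points lower from compound 1 to compound 2 (within the scatter). Compound 3 differs from compound 1 in the other part of the molecule, (1H-1,2,4-triazol-1-yl in place of 1H-imidazol-1-yl on an aromatic carbon), with a step of a number 4.2 percentage points lower from compound 1 to compound 3 (within the scatter). All three numbers lie within the usual scatter of one another, so none of them can be called higher or lower than another with any confidence.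

Compound 4, `Clc1ccc(-c2csc(N/N=C/c3ccc(-n4cncn4)cc3)n2)c(Cl)c1`, has not yet been measured in this assay. It stands to compound 3 as compound 2 stands to compound 1: the change is 2,4-dichlorophenyl in place of 4-bromophenyl on an aromatic carbon. The surroundings of the place are described in the same words for both pairs, so this is the same change, made once on the core of compound 1 and now on the core of compound 3.

The expected step is estimated at a number 5.6 percentage points lower from compound 3 to compound 4 (within the scatter), a figure that rests on the measured step of a number 8 percentage points lower from compound 1 to compound 2 (within the scatter), which was itself within the scatter. Compound 4 is therefore expected to give about 27%, with a likely range from 15% to 40%.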

Compound 4, a percentage reported as inhibition, at one concentration (the size of the read-out at that concentration, not a potency): 8.9%
Compound 4: the middle estimate sits 18.1 percentage points above what was measured; the whole stated range lies above it.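

In this assay, 2,4-dichlorophenyl in place of 4-bromophenyl now gives a number 23.7 percentage points lower from compound 3 to compound 4 (beyond the scatter), so the size of this change did not carry over from the core of compound 1 to the core of compound 3: the same change on two cores in this assay, a number 8 percentage points lower (within the scatter) from compound 1 to compound 2 and a number 23.7 percentage points lower (beyond the scatter) from compound 3 to compound 4, 15.7 percentage points apart, beyond the scatter of two such steps. Read from the other side, 1H-1,2,4-triazol-1-yl in place of 1H-imidazol-1-yl gives a number 19.9 percentage points lower from compound 2 to compound 4 (beyond the scatter), and this change also differs with its surroundings: the same change on two cores in this assay, a number 4.2 percentage points lower (within the scatter) from compound 1 to compound 3 and a number 19.9 percentage points lower (beyond the scatter) from compound 2 to compound 4, 15.7 percentage points apart, beyond the scatter of two such steps. Both comparisons rest on the same four compounds, so they amount to a single observation that the two changes do not simply add up in this small set, and they show neither why that is nor whether it would hold for any other pair of groups.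

The compounds shown leave open whether a single chlorine, as in 4-chlorophenyl, or an unsubstituted phenyl would give a step like that of 2,4-dichlorophenyl on the core of compound 3. They also leave open whether the same dependence on the core would appear with a different group in place of the 1H-imidazol-1-yl, such as a pyrazole or an amine.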